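The compounds below may be only part of what the source reports. "The series", "measured", "known", "first", "only" and "open" are said of these compounds alone.

Three ureas built on one shared core have been measured in an ADME assay on the whole organism with Oryza sativa as the target, tested at 10 uM; on this read-out higher numbers stand for a weaker effect at the one concentration tested and lower numbers for a stronger effect. Compound 1 `Cc1cccc(NC(=O)N[C@H](C)c2ccccc2)c1` gives 47%. Compound 2 `Cc1cccc(NC(=O)N[C@@H](C)c2ccccc2)c1` differs from compound 1 only in drawn configuration; in this read-out compound 2 gives 100%, and compound 3 `CCCc1ccc(NC(=O)N[C@H](C)c2ccccc2)cc1` gives 35%. Among these three numbers compound 1 stands second highest: compound 3 lies below it beyond the scatter, and compound 2 lies far above it.

For the measured compounds named here, the only step between two compounds that differ in a single place is a number 53 percentage points higher from compound 1 to compound 2 (beyond the scatter). Because (the fact that compounds 1 and 2 differ only in the configuration as drawn), this step shows how much the drawn configuration alone can move the read-out, and it says nothing about groups on the aromatic ring. Compound 3 differs from compound 1 in more than one place, so its value serves only as a second point of reference.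

Compound 4 `CCOC(=O)c1cccc(NC(=O)N[C@H](C)c2ccccc2)c1` is the next compound to be measured. It differs from compound 1 by ethoxycarbonyl in place of methyl on an aromatic carbon. Going by the values given here, no measured step touches a change of this kind, so there is no basis to expect a move beyond the scatter in either direction. The step of no change at the digits printed from compound 1 to compound 4 (within the scatter) that is expected is therefore small. Compound 4 is expected to give about 47% in this assay, with a range from 22% to 75%. Among the compounds with values here, the range is wide, as the change itself has no measured counterpart.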

Compound 4, a percentage reported as activity, at one concentration (the size of the read-out at that concentration, not a potency): 88%
Estimate against measurement, compound 4: 41 percentage points below; the whole stated range lies below it.
By their numbers in this assay, from the lowest: compound 3; then compound 1; then compound 4; then compound 2.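

In this assay, putting ethoxycarbonyl in place of methyl on this aromatic carbon gives a number 41 percentage points higher from compound 1 to compound 4 (beyond the scatter), so on this read-out the effect at the one concentration tested is weaker with ethoxycarbonyl. For the compounds shown here, this is the first measured step at a place on the aromatic ring, and it shows that the read-out responds to what sits at this position, not only to the drawn configuration that separated the earlier pair. No measurement shown gives a reason for the size of this step.

The change brings in more heavy atoms, a double bond outside the aromatic ring and hydrogen-bond acceptors all at once, and the compounds shown cannot tell these apart; a carboxylic acid, an ethyl group or a methoxy group on the same carbon would each separate some of them. Also open, from the compounds shown here alone, is whether ethoxycarbonyl would have a similar effect on another carbon of the ring, or in a compound drawn with the opposite configuration at the chain carbon.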